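Replacing the thiazolylamino arm of compound 3

The source may hold more compounds than are shown below. What is called first, only, known or untested is meant among the compounds shown, and "the series" means these compounds.

Of the compounds shown here, three sharing one core have been measured. Compound 1 `CC(C)C(c1ncc[nH]1)c1ccc(-c2ccc3cccc(F)c3c2)[nH]c1=O` gives 33 nM in a functional assay on CHO cells for antagonist activity at prostaglandin E2 receptor EP3 subtype (Homo sapiens), read by cAMP accumulation; on this read-out higher numbers stand for weaker inhibition and lower numbers for stronger inhibition; compound 2 `CC(C)C(c1nnc[nH]1)c1ccc(-c2ccc3cccc(F)c3c2)[nH]c1=O` gives 21 nM; compound 3 `CC(C)C(Nc1nccs1)c1ccc(-c2ccc3cccc(F)c3c2)[nH]c1=O` gives 10 nM. Compound 3 stands lowest of the three, with compound 2 nearest and compound 1 furthest. The steps leading to it were a 3.3-fold lower number from compound 1 to compound 3 (0.52 log units; beyond the scatter) and a 2.1-fold lower number from compound 2 to compound 3 (0.32 log units; beyond the scatter), while a 1.6-fold lower number from compound 1 to compound 2 (0.20 log units; within the scatter).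

Compound 4 `CC(C)C(/C=C1\CCNC1=O)c1ccc(-c2ccc3cccc(F)c3c2)[nH]c1=O` differs from compound 3 in one place: a group of 7 heavy atoms (5 carbon, 1 nitrogen, 1 oxygen; one five-membered non-aromatic ring with 1 hetero atom) in place of a group of 6 heavy atoms (3 carbon, 2 nitrogen, 1 sulfur; one five-membered aromatic ring with 2 hetero atoms), on a saturated chain carbon bound to an aromatic carbon and a saturated chain carbon

For the measured compounds named here, no measured step swaps the arm for a non-aromatic ring, so the steps to compound 3 bear only loosely: both show that the arm matters and that the two aromatic alternatives gave higher numbers than compound 3. With the aromatic ring and the amine linker both gone, a modest rise back toward the range of compounds 1 and 2 is the expectation, so a 2.5-fold higher number from compound 3 to compound 4 (0.40 log units; beyond the scatter) is estimated. For compound 4 the estimate in this assay is 25 nM, expected to fall between 8 nM and 80 nM.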

Compound 4, half-maximal inhibitory concentration: 8.7 nM
Estimate against measurement, compound 4: 2.9-fold (0.46 log units) above; the measured number falls inside the stated range.
By their numbers in this assay, from the lowest: compounds 4 and 3 (each within the scatter of the next); then compounds 2 and 1 (each within the scatter of the next).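

In this assay, the position on the saturated chain carbon accepts a non-aromatic ring arm as well as the (1,3-thiazol-2-yl)amino arm: a 1.1-fold lower number from compound 3 to compound 4 (0.06 log units; within the scatter), so among these compounds neither an aromatic ring nor an amine linker in the arm is required to reach this level. The same change also stands beyond the scatter against the two aromatic arms, with a 2.4-fold lower number from compound 2 to compound 4 (0.38 log units; beyond the scatter) for the 4H-1,2,4-triazol-3-yl arm and a 3.8-fold lower number from compound 1 to compound 4 (0.58 log units; beyond the scatter) for the 1H-imidazol-2-yl arm. Nothing measured here explains why two such different arms give matching numbers.

On these data alone, it remains open which part of the new arm matters: the ring carbonyl, the amide hydrogen or the double bond joining the ring to the chain. As far as these compounds go, how a carboxylic acid or an open-chain amide would behave at this position also remains unknown.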